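Amino in place of hydrogen on a second core

The compounds below may be only part of what the source reports. "The series", "measured", "known", "first", "only" and "open" are said of these compounds alone.

Two cores carry the same set of changes. Compound 1 `CCn1cc(-c2nc3ccccc3[nH]2)c(=O)c2cc(F)c(N3CCNCC3)cc21` and compound 2 `CCn1cc(-c2nc3ccccc3[nH]2)c(=O)c2cc(F)c(N3CCNCC3)nc21` differ by a larger part of the molecule, and the difference between the two cores is not broken down here. In a functional assay on A549 cells (Homo sapiens) for cytotoxicity, read by sulforhodamine B assay, with a stated time of 48 h (a lower number here means a stronger inhibitor, a higher number a weaker inhibitor), compound 1 gives 4700 nM. In this assay compound 2 gives 7800 nM; these two values lie within the usual scatter of each other, so no order between them is claimed.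

Compound 3 `CCn1cc(-c2nc3ccc(N)cc3[nH]2)c(=O)c2cc(F)c(N3CCNCC3)cc21` is derived from compound 1 by the change (amino in place of hydrogen on an aromatic carbon). In this assay compound 3 gives only a limit of the assay, > 10000 nM, and no number. The step of an at least 2.1-fold higher number from compound 1 to compound 3 (0.32 log units; beyond the scatter) is therefore only a lower bound on the loss, which follows from the limit of > 10000 nM in this assay, at which 1 of the 3 values shown sits.

Compound 4 `CCn1cc(-c2nc3ccc(N)cc3[nH]2)c(=O)c2cc(F)c(N3CCNCC3)nc21` stands to compound 2 exactly as compound 3 stands to compound 1: the change amino in place of hydrogen on an aromatic carbon is the same change, made on the same place of the shared part. Among the measured compounds shown here, since the only measured instance of this change, an at least 2.1-fold higher number from compound 1 to compound 3 (0.32 log units; beyond the scatter), reached the limit, the step from compound 2 to compound 4 in this assay is expected to be at least as large, which is a 2.6-fold higher number from compound 2 to compound 4 (0.41 log units; beyond the scatter). Starting from the value of compound 2, 7800 nM, compound 4 is expected to give about 20000 nM in this assay, within a range of 10000 nM to 50000 nM. Compound 4 is expected, most likely, to be reported only as a limit of the assay.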

Compound 4, half-maximal inhibitory concentration: > 10000 nM
Compound 4: a limit, no number; the forecaster's own chance of this, stated with the estimate: 70%; the middle value is on the limit's open side.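

In this assay compound 4 gives > 10000 nM, which is a limit of the assay and not a number, so both amino compounds now end at the same limit: the limit of > 10000 nM in this assay, at which 2 of the 4 values shown sit.

On the second core the change reads as an at least 1.2-fold higher number from compound 2 to compound 4 (0.10 log units; that floor lies within the scatter), so this result does not run against the step on the first core, but on its own it does not establish a loss beyond the scatter. The size of the change therefore cannot be compared between the two cores, and the result shows only that both amino compounds reach the limit, not that the change has the same size on each: the same change on two cores in this assay, an at least 2.1-fold higher number (0.32 log units; beyond the scatter) from compound 1 to compound 3 and an at least 1.2-fold higher number (0.10 log units; that floor lies within the scatter) from compound 2 to compound 4; the limit leaves it open whether they differ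

The compounds shown leave open how far past the limit compound 3 and compound 4 lie, and a read-out that gives numbers for both would be needed before the two steps could be set side by side. They also leave open what other groups on the same aromatic carbon, such as a methoxy group, a nitro group or a carboxylic acid, would do on either core.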